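The source may hold more compounds than are shown below. What is called first, only, known or untested is meant among the compounds shown, and "the series" means these compounds.

Measured so far in a functional assay on A549 cells (Homo sapiens) for inhibition, read by sulforhodamine B assay; on this read-out lower numbers stand for stronger inhibition of growth and higher numbers for weaker inhibition of growth:
- compound 1 `O=C1NC(=S)S/C1=C\c1cc(Cl)ccc1OCc1ccccc1` gives 5000 nM
- compound 2 `O=C1NC(=S)S/C1=C\c1cc(Br)ccc1OCc1ccccc1` gives 7000 nM
- compound 3 `O=C1NC(=O)/C(=C/c2cc(Cl)ccc2OCc2ccccc2)S1` gives 5000 nM

Compound 1 and compound 2 share one core and differ in a single place: bromo in place of chloro on an aromatic carbon. In this assay this gave a 1.4-fold higher number from compound 1 to compound 2 (0.15 log units; within the scatter). Compound 3 carries a different core; the difference between the two cores is not broken down here. In this assay compound 3 stands level with compound 1 at the digits reported, and its gap to compound 2 is within the scatter.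

Compound 4 `O=C1NC(=O)/C(=C/c2cc(Br)ccc2OCc2ccccc2)S1` has not been measured. It relates to compound 3 as compound 2 relates to compound 1, the same change at the same place: bromo in place of chloro on an aromatic carbon. Because the step of a 1.4-fold higher number from compound 1 to compound 2 (0.15 log units; within the scatter) stayed within the scatter, the expectation for the same change on the core of compound 3 is a step of similar size, estimated as a 1.4-fold higher number from compound 3 to compound 4 (0.15 log units; within the scatter). Compound 4 is therefore estimated at 7000 nM in this assay, expected to fall between 3000 nM and 16000 nM.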

Compound 4, concentration for 50% growth inhibition: 5000 nM
Estimate against measurement, compound 4: 1.4-fold (0.15 log units) above; the range from low to high includes it.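

In this assay, bromo in place of chloro on an aromatic carbon gave no change at the digits printed from compound 3 to compound 4 (within the scatter). Set beside the earlier step, the change reads alike on the two cores: the same change on two cores in this assay, a 1.4-fold higher number (0.15 log units; within the scatter) from compound 1 to compound 2 and no change at the digits printed (within the scatter) from compound 3 to compound 4, 1.4-fold (0.15 log units) apart, within the scatter of two such steps. This shows that, for this one halogen swap at this one place, the step carries over from one core to the other without a difference that can be told from the scatter, but both steps are themselves within the scatter, so the carry-over is tested only on a change with no readable effect in this assay, and it gives no rule for other cores, other changes or other read-outs.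

The compounds shown leave open whether a group other than a halogen at this place, such as a methoxy group, an amine or a carboxylic acid, would give a step beyond the scatter, and whether such a step would then carry from one core to the other. Also open, on these data alone, is whether a longer chain on the ether oxygen would make the two cores behave differently.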